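The source may hold more compounds than are shown below. What is called first, only, known or untested is meant among the compounds shown, and "the series" means these compounds.

In a functional assay on Hep 3B2 cells (Homo sapiens) for antiproliferative activity, read by sulforhodamine B assay, with a stated time of 48 h (on this read-out lower numbers stand for stronger inhibition of growth and higher numbers for weaker inhibition of growth), compound 1 (`CC(C)CCc1c(OCCCCCCC(=O)NO)ccc2c1OC(=O)CC2`) stands at > 30000 nM as a limit of the assay and not a number. Compound 2 (`CC(C)CCc1c(OCCCCCCC(=O)NO)ccc2ccc(=O)oc12`) gives 750 nM in this assay as a measured number. Compound 3 (`CC(C)CCc1c(OCCCCCCCC(=O)NO)ccc2c1OC(=O)CC2`) keeps the core of compound 1 and differs only in the chain ((hydroxycarbamoyl)methyl in place of hydroxycarbamoyl on a saturated chain carbon, six bonds along the chain from an oxygen on an aromatic ring), with (hydroxycarbamoyl)methyl in place of hydroxycarbamoyl on a saturated chain carbon, six bonds along the chain from an oxygen on an aromatic ring. Going by the values given here, no measured step shows the size of this change. The estimated step of a number no higher from compound 1 to compound 3 (the limit leaves the size open) is expected to stay within the scatter in this assay and to have no clear direction. Compound 3 is expected at 30000 nM with an estimated range from 8000 nM to 60000 nM for this compound.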

Compound 3, concentration for 50% growth inhibition: > 30000 nM
Compound 3: a limit, no number (the forecaster's own chance of this, stated with the estimate: 65%); the middle value sits exactly at the limit.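

No step can be read between compound 1 and compound 3, as both stand at a limit and not a number in this assay, namely: the limit of > 30000 nM in this assay, at which 2 of the 3 values shown sit.

On these data alone, whether (hydroxycarbamoyl)methyl in place of hydroxycarbamoyl changes growth inhibition on the core of compound 1 stays open.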